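The source may hold more compounds than are shown below. What is called first, only, known or untested is meant among the compounds shown, and "the series" means these compounds.

Working notes on the series. Compound 1 `CNc1nc(N)n2nc(-c3ccco3)nc2n1` is the reference point. In a functional assay on CHO cells for antagonist activity at adenosine receptor A2b (Homo sapiens) (on this read-out higher numbers stand for weaker inhibition and lower numbers for stronger inhibition), compound 1 gives only a limit of the assay, > 30000 nM. Within the data shown here, compound 2 `CC(C)Nc1nc(N)n2nc(-c3ccco3)nc2n1` is the one other measured member. In this assay compound 2 likewise returns only the limit, > 30000 nM. Among the measured compounds shown here, the step that the two limits leave unreadable from compound 1 to compound 2 therefore cannot be read, and the limit of > 30000 nM in this assay, at which 2 of the 2 values shown sit, is the only evidence on the measured steps. Compound 3 `CNc1nc(NCc2ccc(F)cc2)n2nc(-c3ccco3)nc2n1` differs from compound 1 by 4-fluorobenzyl in place of hydrogen on a nitrogen on an aromatic ring. For the measured compounds named here, no measured step bears on this change, since the one step recorded, isopropyl for methyl at the other nitrogen, is unreadable between two limits. Going by the values given here, the size of the step to compound 3 in this assay is thus expected to be uncertain in both direction and magnitude, and the estimated step of an at least 3.7-fold lower number from compound 1 to compound 3 (0.57 log units; beyond the scatter) rests on no measured precedent. Compound 3 is estimated at 8000 nM, within a range from 800 nM to 30000 nM.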

Compound 3, half-maximal inhibitory concentration: > 30000 nM
Compound 3: a limit, no number (the forecaster's own chance of this, stated with the estimate: 45%); at least 3.7-fold (0.57 log units) between middle value and limit.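

In this assay compound 3 gives > 30000 nM, a limit and not a number, so the step from compound 1 to compound 3 cannot be read. The compounds shown leave open whether either change on a nitrogen alters inhibition: the limit of > 30000 nM in this assay, at which 3 of the 3 values shown sit.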